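The compounds below may be only part of what the source reports. "The series", "measured", "known", "first", "only" and "open" are said of these compounds alone.

Compound 1 `CC(C)Oc1ccc(Cc2ccc(NC3=NCCN3)cc2)cc1`: 8.8
Compound 2 `c1cc(NC2=NCCN2)ccc1Cc1ccc(OC2CCCC2)cc1`: 8.9

In a functional assay on SH-SY5Y cells (Homo sapiens) for antagonist activity, read by cAMP accumulation (a lower number here means a less potent compound, a higher number a more potent compound, by a factor of ten per unit of this negative logarithm), compound 2 stands level with compound 1, as a number 0.10 log units higher from compound 1 to compound 2 (within the scatter) shows. Compound 3 `c1cc(NC2=NCCN2)ccc1Cc1ccc(OCC2CCOCC2)cc1` has (oxan-4-yl)methyl in place of cyclopentyl on an oxygen on an aromatic ring. Going by the values given here, the only measured change at that place, a number 0.10 log units higher from compound 1 to compound 2 (within the scatter), is small, but no measured compound has a hetero atom in this group. The size of this new change is therefore uncertain, and a modest drop is expected, a number 0.40 log units lower from compound 2 to compound 3 (beyond the scatter). Compound 3 is estimated at 8.5, with an expected range of 7.9 to 9.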

Compound 3, negative logarithm of the antagonist equilibrium constant: 8.5
The estimate for compound 3 equals the measured number at the digits printed, within the range that was stated.
By their numbers in this assay, from the lowest: compounds 3, 1 and 2 (each within the scatter of the next, the first and the last beyond it).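

Moving to the first group here with a hetero atom in its ring gives a number 0.40 log units lower from compound 2 to compound 3 (beyond the scatter) in this assay, so this position does respond to the change. Going by these compounds alone, measured from isopropyl, the same group gives a number 0.30 log units lower from compound 1 to compound 3 (within the scatter), so only the step from cyclopentyl clears the scatter. No measurement here accounts for that step.

Cyclopentyl and (oxan-4-yl)methyl differ in ring size, ring oxygen and methyl link all at once, so the step cannot be pinned on any one of them. From the compounds shown here alone, whether cyclohexylmethyl, with carbon only, or a ring carrying an amine would hold the number stays open.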